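Adding a second methyl to compound 1

This account rests on a few compounds, and the source may have more. Where it says the series, first, only, none or still open, it means among the compounds named here.

Measured so far:
compound 1 `Cc1cccc(Nc2nccc(-c3cccs3)n2)c1` — 300 nM
compound 2 `COc1cccc(Nc2nccc(-c3cccs3)n2)c1` — 900 nM

In a functional assay for inhibition, with Homo sapiens as the target (a higher number here means a weaker inhibitor, a lower number a stronger inhibitor), compound 1 gives 300 nM, the lower of the two numbers; compound 2 gives 900 nM. Among the measured compounds shown here, the only measured step, a 3.0-fold higher number from compound 1 to compound 2 (0.48 log units; beyond the scatter), exchanges one group for another and does not bear directly on the change to compound 3 `Cc1cc(C)cc(Nc2nccc(-c3cccs3)n2)c1`, which is methyl in place of hydrogen on an aromatic carbon. For the measured compounds named here, no measured step adds a group to the shared core, so there is nothing to support a shift in either direction. For compound 3 the expected step is no change at the digits printed from compound 1 to compound 3 (within the scatter), none beyond the scatter. Compound 3 is therefore estimated at 300 nM, within 100 nM to 900 nM.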

Compound 3, half-maximal inhibitory concentration: 4300 nM
Compound 3: the middle estimate sits 14-fold (1.16 log units) below what was measured; the measured number lies above the stated range.
By their numbers in this assay, from the lowest: compound 1; then compound 2; then compound 3.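

In this assay, methyl in place of hydrogen on this aromatic carbon, meta to a large group and meta to a methyl group, gives a 14-fold higher number from compound 1 to compound 3 (1.16 log units; beyond the scatter) and is a large step. A single added carbon at this position is therefore not tolerated silently, which the exchange of methyl for methoxy in compound 2 could not show. Nothing available accounts for the size of this step.

On these data alone, whether the loss is particular to methyl remains open. A fluorine, a chlorine or an amine on this carbon would show whether any replacement of hydrogen here raises the number.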